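The source may hold more compounds than are shown below. What is called first, only, known or untested is meant among the compounds shown, and "the series" means these compounds.

Measured in a functional assay on NCI-H23 cells (Homo sapiens) for cytotoxicity, read by sulforhodamine B assay, tested at 10 uM; on this read-out lower numbers stand for less inhibition and higher numbers for more inhibition at the one concentration tested (going by the name of the read-out):
- compound 1 `CC(=O)OC[C@H]1O[C@@H](n2cc(-c3cn(Cc4ccccc4)nn3)c(=O)[nH]c2=O)C[C@@H]1OC(C)=O`: 98.2%
- compound 2 `CC(C)(C)c1ccc(Cn2cc(-c3cn([C@H]4C[C@H](O)[C@@H](CO)O4)c(=O)[nH]c3=O)nn2)cc1`: 95%
- compound 3 `O=c1[nH]c(=O)n([C@H]2C[C@H](O)[C@@H](CO)O2)cc1-c1cn(Cc2ccccc2)nn1`: 97.5%

Among the compounds with values here, all three values in this assay sit close together, and no pair is separated by more than the usual scatter, so no order among compound 1, compound 2 and compound 3 can be read from them. Within the data shown here, the one change measured within the set is tert-butyl in place of hydrogen on an aromatic carbon, which gives a number 2.5 percentage points lower from compound 3 to compound 2 (within the scatter). Compound 1 and compound 3 carry different cores; the difference between the two cores is not broken down here.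

Compound 4 `CC(=O)OC[C@H]1O[C@@H](n2cc(-c3cn(Cc4ccc(C(C)(C)C)cc4)nn3)c(=O)[nH]c2=O)C[C@@H]1OC(C)=O` has not been measured. Among the measured compounds shown here, it differs from compound 1 by tert-butyl in place of hydrogen on an aromatic carbon, the same change as the one measured from compound 3 to compound 2, at the same place. The step expected from compound 1 to compound 4 in this assay is a number 2.2 percentage points lower from compound 1 to compound 4 (within the scatter), set beside the measured step of a number 2.5 percentage points lower from compound 3 to compound 2 (within the scatter), which it is expected to resemble because a number 2.5 percentage points lower from compound 3 to compound 2 (within the scatter) lies within the scatter. Compound 4 is therefore estimated at 96%, with a range from 90% to 99.5%.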

Compound 4, a percentage reported as inhibition, at one concentration (the size of the read-out at that concentration, not a potency): 106%
The estimate for compound 4 lay 10 percentage points below the measured number; measured number above the stated range.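

On the core of compound 1, tert-butyl in place of hydrogen on an aromatic carbon gives a number 7.8 percentage points higher from compound 1 to compound 4 (within the scatter) in this assay. Set beside the step on the other core, the change does not read differently between the two cores: the same change on two cores in this assay, a number 2.5 percentage points lower (within the scatter) from compound 3 to compound 2 and a number 7.8 percentage points higher (within the scatter) from compound 1 to compound 4, 10.3 percentage points apart, within the scatter of two such steps This is consistent with the change carrying over from one core to the other but does not establish it: neither step can be told from the scatter, so neither gives a measured effect of tert-butyl on its own, and a read-out at one concentration gives no potency.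

The compounds shown leave open how an amine, a carboxylic acid or a longer chain in place of the tert-butyl would read in this assay. They also leave open whether a difference between the two cores, or between hydrogen and tert-butyl, would appear as a stronger or weaker effect at a concentration other than the one tested.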